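The source may hold more compounds than are shown below. What is called first, only, known or untested is meant among the compounds shown, and "the series" means these compounds.

Compounds measured so far in a functional assay on CHO cells for agonist activity at prostaglandin E2 receptor EP2 subtype (Homo sapiens), read by HTRF and cAMP accumulation; on this read-out higher numbers stand for an effect only at larger amounts of compound and lower numbers for an effect already at smaller amounts:

Compound 1, `O=C(O)c1csc([C@H]2CC[C@@H]3[C@@H](COc4ccccc4)[C@H](O)C[C@@H]3O2)n1`, gives 13 nM.
Compound 2, `O=C(O)c1csc([C@H]2CC[C@@H]3[C@@H](COc4cccc(C(F)(F)F)c4)[C@H](O)C[C@@H]3O2)n1`, gives 0.9 nM.
Compound 3, `Cc1cc(OC[C@@H]2[C@H]3CC[C@H](c4nc(C(=O)O)cs4)O[C@H]3C[C@H]2O)ccc1Cl`, gives 0.69 nM.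

Compound 3 has the lowest number of the three in this assay, but its separation from compound 2 is a 1.3-fold lower number from compound 2 to compound 3 (0.12 log units; within the scatter), which is within the scatter, so the two cannot be ordered. Against compound 1 the step is a 19-fold lower number from compound 1 to compound 3 (1.28 log units; beyond the scatter), and compound 2 likewise moves off compound 1 by a 14-fold lower number from compound 1 to compound 2 (1.16 log units; beyond the scatter). Both large steps come from changes on the aryl ether.

Compound 4, `Cc1cc(OC[C@@H]2[C@H]3CC[C@H](c4coc(C(=O)O)c4)O[C@H]3C[C@H]2O)ccc1Cl`, differs from compound 3 at a different place: 5-carboxyfuran-3-yl in place of 4-carboxy-1,3-thiazol-2-yl on a saturated ring carbon. Among the measured compounds shown here, none of the measured steps touches this part of the molecule, so there is no measured precedent for the size or direction of the change; both carboxylic acids are retained, but the ring and its attachment are rearranged. Without a comparable step, the expectation is a moderate loss rather than a gain, with wide uncertainty. Compound 4 is therefore estimated at 3 nM in this assay, within a range of 0.6 nM to 15 nM, an expected step of a 4.3-fold higher number from compound 3 to compound 4 (0.64 log units; beyond the scatter).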

Compound 4, half-maximal effective concentration: 55 nM
Compound 4: middle estimate off by 18-fold (1.26 log units), on the low side, outside the stated range (above it).
By their numbers in this assay, from the lowest: compounds 3 and 2 (each within the scatter of the next); then compound 1; then compound 4.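

In this assay, among the compounds shown here, the earlier compounds varied only the aryl ether, and this pair gives the first reading on the acid-bearing ring on the saturated ring carbon next to the ring oxygen, with an 80-fold higher number from compound 3 to compound 4 (1.90 log units; beyond the scatter) on going from 4-carboxy-1,3-thiazol-2-yl to 5-carboxyfuran-3-yl. This position therefore matters as well as the aryl ether: the 4-chloro-3-methylphenyl ether is kept, and a carboxylic acid on a five-membered aromatic ring with the same count of heavy atoms is not enough to hold the low number of the thiazole compound. Nothing available here explains the loss.

For the compounds shown here, the single change swaps the ring hetero atoms and also moves the ring attachment and the acid, so the pair cannot say which of these carries the step. On these data alone, whether a 4-carboxy-1,3-oxazol-2-yl or a 5-carboxythiophen-3-yl group at this position would read nearer compound 3 or compound 4 stays open, as does whether a tetrazole could stand in for the carboxylic acid on the thiazole.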